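Thiophene-Piperidine Replacement: Expected Lipophilicity of Compound 4

This account rests on a few compounds, and the source may have more. Where it says the series, first, only, none or still open, it means among the compounds named here.

Compound 2 `COc1ncc(C2=CCOCC2)cc1S(=O)(=O)Nc1cncc(C2=CCN(C)CC2)c1` gives 1.5 in a physicochemical assay for lipophilicity (on this read-out higher numbers stand for higher lipophilicity and lower numbers for lower lipophilicity), the second highest of the three numbers. Compound 1 `COc1ncc(C2=CCOCC2)cc1S(=O)(=O)Nc1cncc(C2CC2CN(C)C)c1` gives 1.2 in this assay, and the step of a number 0.30 log units higher from compound 1 to compound 2 (within the scatter) lies within the scatter. Compound 3 `COc1ncc(C2=CCOCC2)cc1S(=O)(=O)Nc1cncc(-c2ccc(N3CCN(C(C)C)CC3)cc2)c1` gives 3.8 in this assay, beyond the scatter above compound 2. Compound 4 `COc1ncc(C2=CCOCC2)cc1S(=O)(=O)Nc1cncc(-c2ccc(CN3CCCCC3)s2)c1` differs from compound 2 by a group of 12 heavy atoms (10 carbon, 1 nitrogen, 1 sulfur; one five-membered aromatic ring with 1 hetero atom, one six-membered non-aromatic ring with 1 hetero atom) in place of a group of 7 heavy atoms (6 carbon, 1 nitrogen; one six-membered non-aromatic ring with 1 hetero atom), on an aromatic carbon. The exchange from compound 1 to compound 2 at the same place hardly moved the number, whereas the change to compound 4 brings in a larger group with an added aromatic ring, closer in kind to compound 3, whose value 3.8 stands far higher. The estimated step of a number 1.80 log units higher from compound 2 to compound 4 (beyond the scatter) is therefore expected to be clearly upward. Compound 4 is expected to give 3.3 in this assay, within 2.6 to 4.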

Compound 4, distribution coefficient: 4.7
The estimate for compound 4 lay 1.40 log units below the measured number; the whole stated range lies below it.
By their numbers in this assay, from the lowest: compounds 1 and 2 (each within the scatter of the next); then compound 3; then compound 4.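

In this assay, this place on the aromatic carbon proved able to carry a far larger change than the earlier step showed: 5-((piperidin-1-yl)methyl)thiophen-2-yl gives a number 3.20 log units higher from compound 2 to compound 4 (beyond the scatter), and a number 3.50 log units higher from compound 1 to compound 4 (beyond the scatter). Compound 3 gives 3.8, and compound 4 gives 4.7, so the printed values also put the thiophene compound above the other compound with an added aromatic ring. Nothing at hand accounts for the size of these steps. The compounds shown leave open how the rise divides between the thiophene ring and the piperidine; a 5-((dimethylamino)methyl)thiophen-2-yl group would help separate the two.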